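The source may hold more compounds than are shown below. What is called first, only, known or untested is meant among the compounds shown, and "the series" means these compounds.

Compound 1 (`CC(=O)Nc1ccc(-c2nc3ccccc3s2)cc1Cl`), compound 2 (`CC(=O)N(C(C)=O)c1ccc(-c2nc3ccccc3s2)cc1`) and compound 3 (`CC(=O)N(C(C)=O)c1ccc(-c2nc3ccccc3s2)cc1C`) are known in a functional assay on MDA-MB-468 cells (Homo sapiens) for antiproliferative activity (on this read-out higher numbers stand for weaker inhibition and lower numbers for stronger inhibition), only as limits. Compound 1 gives the limit > 100 nM. Compound 2 gives the limit > 100 nM. Compound 3 gives the limit > 10000 nM, and so has no exact position in the series.

Compound 4 (`CC(=O)N(C(C)=O)c1ccc(-c2nc3ccccc3s2)cc1Cl`) carries one change: chloro in place of methyl on an aromatic carbon, chloro in place of methyl, ortho to a diacetylamino group. Within the data shown here, the only measured step that bears on it is a step that the two limits leave unreadable from compound 2 to compound 3, which supplies no size to carry over. Compound 1 also carries chloro, but has a different acetyl substitution. A moderate, uncertain step towards stronger inhibition in this assay is expected, namely an at least 2.0-fold lower number from compound 3 to compound 4 (0.30 log units; that floor lies within the scatter). Compound 4 is estimated at 5000 nM, within an expected range of 200 nM to 30000 nM.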

Compound 4, half-maximal inhibitory concentration: > 1000 nM
Compound 4: no number, only a limit; the forecaster's own chance of this, stated with the estimate: 75%; the middle value lies beyond the limit too.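

Compound 4 is known only as a limit, as are compound 1, compound 2 and compound 3, so none of its steps from them can be read. The compounds shown leave open whether chloro, methyl or a second acetyl shifts inhibition at all.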